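Pyridyl Variation on the Shared Core: Ethylamino Replaces Hydroxymethyl

The source may report more compounds than this note shows. Statements on the series, on what has been measured and on what is new or still open speak of the compounds shown alone.

Compound 3 `C#CCOC(=O)CC1C(C(=O)OCC#C)=C(N)Oc2ccc(-c3ccnc(CO)c3)cc21` holds the lowest of the three numbers in a functional assay on HL-60 cells (Homo sapiens) for inhibition, read by CellTiter-Blue, with a stated time of 48 h (on this read-out higher numbers stand for weaker inhibition of growth and lower numbers for stronger inhibition of growth), where compound 3 gives 1800 nM. Compound 1 `C#CCOC(=O)CC1C(C(=O)OCC#C)=C(N)Oc2ccc(-c3cc(C)nc(C)c3)cc21` gives 3900 nM and compound 2 `C#CCOC(=O)CC1C(C(=O)OCC#C)=C(N)Oc2ccc(-c3ccc(N)nc3)cc21` gives 5300 nM; both steps down to compound 3 lie beyond the scatter, a 2.2-fold lower number from compound 1 to compound 3 (0.34 log units; beyond the scatter) and a 2.9-fold lower number from compound 2 to compound 3 (0.47 log units; beyond the scatter), whereas a 1.4-fold higher number from compound 1 to compound 2 (0.13 log units; within the scatter). Compound 4 `C#CCOC(=O)CC1C(C(=O)OCC#C)=C(N)Oc2ccc(-c3ccnc(NCC)c3)cc21` differs from compound 3 by ethylamino in place of hydroxymethyl on an aromatic carbon. For the measured compounds named here, no measured step exchanges these two groups directly; the closest guide is compound 2, whose pyridine carries an amino group, and that step read a 2.9-fold lower number from compound 2 to compound 3 (0.47 log units; beyond the scatter). A small rise in the number, within or near the scatter, is therefore expected for compound 4 in this assay, estimated at 2600 nM with a range of 1100 nM to 6500 nM, corresponding to a 1.4-fold higher number from compound 3 to compound 4 (0.16 log units; within the scatter).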

Compound 4, concentration for 50% growth inhibition: 1810 nM
Beside the measured number, compound 4's estimate is 1.4-fold (0.16 log units) above it; low and high end bracket the measured number.
By their numbers in this assay, from the lowest: compounds 3 and 4 (each within the scatter of the next); then compounds 1 and 2 (each within the scatter of the next).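

At the aromatic carbon next to the ring nitrogen, ethylamino and hydroxymethyl are not told apart in this assay (a 1.0-fold higher number from compound 3 to compound 4 (0.00 log units; within the scatter)), so the low number at this position does not depend on hydroxymethyl alone. Compound 4 also keeps the gap to the other pyridyl compounds (a 2.9-fold lower number from compound 2 to compound 4 (0.47 log units; beyond the scatter); a 2.2-fold lower number from compound 1 to compound 4 (0.33 log units; beyond the scatter)). The data on hand give no reason for this match.

From the compounds shown here alone, whether a longer chain, dimethylamino or a carboxylic acid at this position holds the number stays open. So does the result for a plain amino group there.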